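The source may report more compounds than this note shows. Statements on the series, on what has been measured and on what is new or still open speak of the compounds shown alone.

Three compounds share one core: compound 1 `CCCCCCOc1nc(C(C)(C)C)ccc1CNC(=O)C(C)c1ccc(NS(C)(=O)=O)c(F)c1`, compound 2 `CCCCCSc1nc(C(C)(C)C)ccc1CNC(=O)C(C)c1ccc(NS(C)(=O)=O)c(F)c1` and compound 3 `CCCCN(C)c1cc(C(C)(C)C)ccc1CNC(=O)C(C)c1ccc(NS(C)(=O)=O)c(F)c1`. In an assay on cells for antagonist activity at transient receptor potential cation channel subfamily V member 1 (Homo sapiens), read by FLIPR and calcium flux, with a stated time of 6 min (a higher number here means a weaker inhibitor, a lower number a stronger inhibitor), compound 1 gives 2.7 nM, compound 2 gives 3.1 nM and compound 3 gives 1 nM, the lowest of the three numbers. Going by the values given here, the only measured step, a 1.1-fold higher number from compound 1 to compound 2 (0.06 log units; within the scatter), concerns pentylsulfanyl in place of hexyloxy and lies within the scatter. Compound 4 `CC(C(=O)NCc1ccc(C(C)(C)C)cc1N1CCCCC1)c1ccc(NS(C)(=O)=O)c(F)c1` differs from compound 3 by piperidin-1-yl in place of butyl(methyl)amino on an aromatic carbon. Among the compounds with values here, no measured step touches this position or this kind of swap, so the one known step is only a weak guide, and no change beyond the scatter is expected: the estimated step is a 1.5-fold higher number from compound 3 to compound 4 (0.18 log units; within the scatter). For compound 4 in this assay the expected value is 1.5 nM, with a range from 0.5 nM to 5 nM.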

Compound 4, inhibition constant: 1.9 nM
Beside the measured number, compound 4's estimate is 1.3-fold (0.10 log units) below it; the measured number falls inside the stated range.
By their numbers in this assay, from the lowest: compounds 3, 4, 1 and 2 (each within the scatter of the next, the first and the last beyond it).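

In this assay, replacing the open butyl(methyl)amino group with the ring of piperidin-1-yl gives a 1.9-fold higher number from compound 3 to compound 4 (0.28 log units; within the scatter). For this pair, on an aromatic carbon ortho to a large group, tying the chain into a ring while keeping 6 heavy atoms leaves the number within the scatter. Nothing available explains this result.

Going by these compounds, whether a smaller ring such as pyrrolidin-1-yl, or morpholin-4-yl with its added oxygen, would also stay within the scatter remains open. So does the effect of a longer chain on the nitrogen.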